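Fluoro for hydrogen on a shared core in cytotoxicity

A few compounds are considered here, and "the series" means these few. Any claim that something is new, unique, unknown or untested is made for them only; others in the source may bear on it.

Measured in an ADME assay on BJ cells (Homo sapiens) for cytotoxicity, with a stated time of 72 h; on this read-out lower numbers stand for an effect already at smaller amounts and higher numbers for an effect only at larger amounts of compound:
Compound 1, `C=C[C@@](C)(/C=C/c1ccc(Nc2ccc(Cl)c(F)c2)cc1)CCC=C(C)C`: > 36600 nM, a limit of the assay.
Compound 2, `C=C[C@@](C)(/C=C/c1ccc(Nc2ccc(Cl)cc2)cc1)CCC=C(C)C`: > 36600 nM, a limit of the assay.
Compound 3, `C=C[C@@](C)(/C=C/c1ccc(-c2ccccc2)cc1)CCC=C(C)C`: > 36600 nM, a limit of the assay.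

All three measured values sit at the limit of > 36600 nM in this assay, at which 3 of the 3 values shown sit, so none of the steps between them can be sized. The step from compound 2 to compound 1, (fluoro in place of hydrogen on an aromatic carbon), gives a step that the two limits leave unreadable from compound 2 to compound 1. The cores of compound 2 and compound 3 differ by phenyl in place of (4-chlorophenyl)amino on an aromatic carbon, and that step gives a step that the two limits leave unreadable from compound 2 to compound 3. Compound 1 and compound 3 likewise give a step that the two limits leave unreadable from compound 1 to compound 3.

Compound 4, `C=C[C@@](C)(/C=C/c1ccc(-c2ccc(F)cc2)cc1)CCC=C(C)C`, is not yet measured in this assay. It differs from compound 3 by fluoro in place of hydrogen on an aromatic carbon. Going by the values given here, this is the same kind of change as the one from compound 2 to compound 1, but the surroundings differ: in compound 1 the fluoro sits ortho to a chloro group and meta to a large group, whereas in compound 4 it sits para to a large group.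

Since every measured compound, including compound 3 at > 36600 nM, reaches only the limit, the expected step from compound 3 to compound 4 is a step that the limit leaves unreadable from compound 3 to compound 4, and compound 4 is expected most likely to be reported again as a limit. The estimate for compound 4 in this assay is 40000 nM, between 18000 nM and 100000 nM.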

Compound 4, half-maximal effective concentration: > 36600 nM
Compound 4: no number, only a limit (the forecaster's own chance of this, stated with the estimate: 85%); the middle value is on the limit's open side.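

In this assay compound 4 gives > 36600 nM, a limit of the assay and not a number. The steps joining compound 4 to compound 1, compound 2 and compound 3 cannot be read, as all four compounds rest on the same limit: the limit of > 36600 nM in this assay, at which 4 of the 4 values shown sit.

The compounds shown leave open at what amount any of them would have an effect in this assay, and whether fluoro in place of hydrogen changes that amount.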